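The source may report more compounds than this note shows. Statements on the series, on what has been measured and on what is new or still open speak of the compounds shown alone.

Measured compounds:

compound 1, `Nc1nc(=O)ccn1[C@@H]1O[C@H](COP(=O)(O)OP(=O)(O)O)[C@@H](O)[C@H]1O` — in an in vitro functional assay on 1321-N1 cells for agonist activity at P2Y purinoceptor 4 (Homo sapiens), read by scintillation proximity assay and inositol phosphate accumulation (a higher number here means that more compound is needed for the effect, a lower number that less compound is needed), compound 1 gives >= 100000 nM
compound 2, `O=c1[nH]c(=S)ccn1[C@@H]1O[C@H](COP(=O)(O)O)[C@@H](O)[C@H]1O` — in this assay compound 2 gives > 100000 nM

The value of compound 1 is a limit of the assay, not a number; compound 1 sits at the limit of >= 100000 nM in this assay, at which 1 of the 2 values shown sits. The value of compound 2 is likewise a limit; compound 2 sits at the limit of > 100000 nM in this assay, at which 1 of the 2 values shown sits. Compound 1 therefore stands nowhere on a scale of numbers: of the two values known, both are limits, and neither compound shows a measurable effect in this assay.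

Compound 3, `CSc1nc(=O)ccn1[C@@H]1O[C@H](COP(=O)(O)OP(=O)(O)O)[C@@H](O)[C@H]1O`, is not yet measured. It differs from compound 1 by methylsulfanyl in place of amino on an aromatic carbon; the rest of the shared core and the diphosphate chain are unchanged. Within the data shown here, no step between two measured compounds is available, so the change has no precedent here. Since compound 1 reports only >= 100000 nM, no step beyond the scatter is expected in either direction; the most probable outcome is that compound 3 also returns a limit. The expected step from compound 1 to compound 3 is a number no higher from compound 1 to compound 3 (the limit leaves the size open). Compound 3 is accordingly estimated at 100000 nM, within a range from 20000 nM to 300000 nM.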

Compound 3, half-maximal effective concentration: 1520 nM
The estimate for compound 3 lay 66-fold (1.82 log units) above the measured number; measured number below the stated range.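

At the position between two ring nitrogen atoms, ortho to a large group, the substituent decides whether any response appears: methylsulfanyl in place of amino on an aromatic carbon gives an at least 65-fold lower number from compound 1 to compound 3 (1.81 log units; beyond the scatter) in this assay. With compound 3 at 1520 nM, the series has its first number rather than a limit, so the shared core and the diphosphate chain can support measurable agonist activity once this one place changes. Compound 1 carries a limit and not a number, so the step fixes only a minimum size and its true size stays open: the limit of >= 100000 nM in this assay, at which 1 of the 3 values shown sits.

The compounds shown do not separate the contribution of the sulfur from that of the added carbon, a question that methoxy, ethylsulfanyl or a free thiol at the same place would address. Compound 2 gives > 100000 nM, which is a limit and not a number. On these data alone, compound 2 also differs from compound 1 in more than one place, so no further steps can be read and the role of the diphosphate chain at this position remains untested.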